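A methoxy for a methyl on the sulfonyl aryl

A few compounds are considered here, and "the series" means these few. Any claim that something is new, unique, unknown or untested is made for them only; others in the source may bear on it.

compound 1 `CCOC(=O)C1CCN(c2c(S(=O)(=O)c3ccccc3)cnc3ccccc23)CC1`: 33%
compound 2 `COc1ccc2ncc(S(=O)(=O)c3ccc(C)cc3)c(N3CCC(C)CC3)c2c1`: 90%
compound 3 `CC1CCN(c2c(S(=O)(=O)c3cc(Cl)cc(Cl)c3)cnc3c(F)cccc23)CC1`: 82%

In an assay on isolated protein for displacement of a labelled ligand from metabotropic glutamate receptor 5 (Homo sapiens), with a stated time of 60 min, tested at 1 uM (a lower number here means less inhibition, a higher number more inhibition at the concentration tested (going by the name of the read-out)), compound 2 gives 90%, the highest of the three numbers. Compound 3 gives 82%, a value within the scatter of that one, whereas compound 1 gives 33%, a gap well beyond the scatter. Compound 4 `COc1cccc(S(=O)(=O)c2cnc3ccc(OC)cc3c2N2CCC(C)CC2)c1` differs from compound 2 in one place: 3-methoxyphenyl in place of 4-methylphenyl on a sulfonyl sulfur. For the measured compounds named here, no measured pair shows this change, so its size is unknown from these data. Compound 2 already stands near the top of the range with 90%, leaving little room upward. The step of a number 10 percentage points lower from compound 2 to compound 4 (within the scatter) is expected to stay within the scatter, if anything a slight fall. Compound 4 is expected to give about 80% in this assay, most likely between 55% and 95%.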

Compound 4, a percentage reported as inhibition, at one concentration (the size of the read-out at that concentration, not a potency): 0%
The estimate for compound 4 lay 80 percentage points above the measured number, outside the stated range (below it).
By their numbers in this assay, from the lowest: compound 4; then compound 1; then compounds 3 and 2 (each within the scatter of the next).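

For the compounds shown here, replacing 4-methylphenyl with 3-methoxyphenyl on a sulfonyl sulfur gives a number 90 percentage points lower from compound 2 to compound 4 (beyond the scatter) in this assay and is the only change here read in a one-place pair. It shows that the group on this sulfonyl sulfur can on its own decide the read-out, since the rest of compound 2 stays unchanged in compound 4. Nothing in the data explains the size of this step.

Going by these compounds alone, the single pair cannot separate the gain of the methoxy oxygen from the loss of the methyl group. From the compounds shown here alone, whether a hydroxyl, an amine or a nitrile on this aryl ring would restore inhibition stays open.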